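This account rests on a few compounds, and the source may have more. Where it says the series, first, only, none or still open, it means among the compounds named here.

The measured compounds:
compound 1, `CC1CN(c2cccnc2)C(=O)c2ccc(Cl)cc21`: in an ADME assay on microsomes from liver (Mus musculus) for metabolic stability, read by LC-MS, using NADPH, with stated times of 10 min and 30 min (on this read-out lower numbers stand for slow clearance and higher numbers for fast clearance), compound 1 gives 45 mL/min/kg.
compound 2, `CCC(=O)N[C@@H]1CCCc2c1cncc2N1Cc2cc(Cl)ccc2C1=O`: in this assay compound 2 gives only a limit, < 20.2 mL/min/kg.

Of the two values shown, compound 1 has a number and compound 2 does not. Compound 2 stands at the limit of < 20.2 mL/min/kg in this assay, at which 1 of the 2 values shown sits, so its clearance is known only as a limit and not as an exact figure, and it cannot be ranked finely against anything else. Compound 3, `CCC(=O)N[C@@H]1CCCc2c1cncc2N1C(=O)c2ccc(Cl)cc2[C@@H]1C`, has not yet been measured in this assay. It differs from compound 2 by methyl in place of hydrogen on a saturated ring carbon. Among the compounds with values here, no measured pair in this set shares that change, so the data give no step size for it, and any expectation must rest on where compound 2 sits. Compound 3 is expected to give 16 mL/min/kg in this assay, with a plausible range from 8 mL/min/kg to 32 mL/min/kg. The expected step that the limit leaves unreadable from compound 2 to compound 3 is judged small, within the usual scatter rather than beyond it, and a reported limit instead of a number is as likely as not for compound 3.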

Compound 3, clearance: < 20.2 mL/min/kg
Compound 3: no number, only a limit; the forecaster's own chance of this, stated with the estimate: 55%; the middle value is on the limit's open side.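

Compound 2 and compound 3 each give only a limit in this assay, not an exact number, so no step can be read between them: the limit of < 20.2 mL/min/kg in this assay, at which 2 of the 3 values shown sit.

The compounds shown leave open the actual clearance of compound 2 and compound 3, and whether methyl in place of hydrogen on a saturated ring carbon changes it at all.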